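The compounds below may be only part of what the source reports. "The series", "measured", "known", "first", "only" and "open" are said of these compounds alone.

Compound 1 `COc1cc(Cc2nc3c(N)nc(F)nc3n2CC2CCCO2)cc(OC)c1OC` gives 22900 nM in a functional assay on MCF7 cells (Homo sapiens) for antiproliferative activity; a lower number here means a stronger inhibitor, a higher number a weaker inhibitor.
Compound 2 `CC/C=C/Cn1c(Cc2cc(OC)c(OC)c(OC)c2)nc2c(N)ncnc21` gives 46800 nM.
Compound 3 `CCCn1c(Cc2cc(OC)c(OC)c(OC)c2)nc2c(N)nc(F)nc21` gives 25100 nM.

Among these three, compound 2 gives the highest number in this assay; its gap to compound 3 lies within the scatter, while its gap to compound 1 lies beyond it, so compound 2 is a weaker inhibitor than compound 1. Compound 4 `C/C=C/Cn1c(Cc2cc(OC)c(OC)c(OC)c2)nc2c(N)ncnc21` differs from compound 2 by hydrogen in place of methyl on a saturated chain carbon bound to a double-bonded chain carbon. For the measured compounds named here, the only measured step, a 1.1-fold higher number from compound 1 to compound 3 (0.04 log units; within the scatter), changed a group at a different place, on a saturated chain carbon bound to an aromatic nitrogen, and stayed within the scatter; no measured step changes the chain on the double-bonded carbon. Going by the values given here, compound 2 is therefore the only guide, and the step of a 1.0-fold lower number from compound 2 to compound 4 (0.02 log units; within the scatter) is expected to stay within the scatter. Compound 4 is estimated at 45000 nM, within 20000 nM to 100000 nM.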

Compound 4, half-maximal inhibitory concentration: 51300 nM
Compound 4: middle estimate off by 1.1-fold (0.06 log units), on the low side; low and high end bracket the measured number.
By their numbers in this assay, from the lowest: compounds 1, 3, 2 and 4 (each within the scatter of the next, the first and the last beyond it).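

In this assay, trimming pent-2-en-1-yl to but-2-en-1-yl gives a 1.1-fold higher number from compound 2 to compound 4 (0.04 log units; within the scatter) and so stays within the scatter. For the compounds shown here, this is the first measured change on this chain, and it shows that removing this single methyl, on a saturated chain carbon bound to a double-bonded chain carbon, does not separate the two compounds. No evidence accompanies this result to explain it.

From the compounds shown here alone, whether a longer chain, or an amine or hydroxyl group at the chain end, would move the number beyond the scatter remains open. So does whether the same trimming would behave alike on the core of compound 3.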